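Moving the nitrile on the cyanophenyl group

This account rests on a few compounds, and the source may have more. Where it says the series, first, only, none or still open, it means among the compounds named here.

Of the compounds shown here, two have numbers so far. In a functional assay on HL-60 cells (Homo sapiens) for inhibition, read by MTT assay, with a stated time of 72 h, tested at 30 uM (on this read-out higher numbers stand for more inhibition of growth at the one concentration tested and lower numbers for less inhibition of growth), compound 1 `C=CCc1ccc(OCc2cn(-c3ccc(C#N)cc3)nn2)c(O)c1` gives 20.8% and stands lowest of the two, while compound 2 `C=CCc1ccc(OCc2cn(-c3cc(OC)c(OC)c(OC)c3)nn2)c(O)c1` gives 32.8% and lies beyond the scatter above it. Compound 3 `C=CCc1ccc(OCc2cn(-c3cccc(C#N)c3)nn2)c(O)c1` has the same atoms as compound 1, joined differently: 3-cyanophenyl in place of 4-cyanophenyl on an aromatic nitrogen with 3-cyanophenyl in place of 4-cyanophenyl on an aromatic nitrogen. No measured single change is available to size this move. With so little to go on, no shift beyond the scatter is expected in this assay in either direction. The estimated a number 2.2 percentage points higher from compound 1 to compound 3 (within the scatter) is expected to be small and to stay within the scatter. Compound 3 is estimated at 23% in this read-out, with an expected range from 12% to 36% until the measurement is in.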

Compound 3, percent growth inhibition at one concentration: 22.5%
Beside the measured number, compound 3's estimate is 0.5 percentage points above it; measured number inside the range.
By their numbers in this assay, from the lowest: compounds 1 and 3 (each within the scatter of the next); then compound 2.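

In this assay, for the compounds shown here, the first single change of the series reads as a number 1.7 percentage points higher from compound 1 to compound 3 (within the scatter) with 3-cyanophenyl in place of 4-cyanophenyl on an aromatic nitrogen. With the atoms unchanged, this shift of the nitrile around the phenyl ring does not separate the two compounds at the one concentration tested, so on this read-out the 3-cyanophenyl and 4-cyanophenyl groups cannot be told apart. Nothing measured here speaks to why the two compounds fall so close together.

Still open is whether the nitrile matters at all at this place, since no compound shown replaces it on the same phenyl ring with an amine or a carboxylic acid. Also open, going by these compounds, is how a longer chain in place of the cyanophenyl group on the aromatic nitrogen would read in this assay on the shared core.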